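The source may hold more compounds than are shown below. What is called first, only, known or untested is meant among the compounds shown, and "the series" means these compounds.

Compound 1 `O=C1CSC(c2cccc(Cl)c2)N1CCN1CCCCC1`: 100%
Compound 2 `O=C1CSC(c2cccc(O)c2)N1CCN1CCCCC1`: 100%
Compound 3 `O=C1CSC(c2ccc(F)cc2)N1CCN1CCCCC1`: 87%

All three were tested in an ADME assay on Vero cells (Chlorocebus sabaeus) for cytotoxicity, read by neutral red uptake, tested at 98 ug/mL; a higher number here means a weaker effect of the compound at the concentration tested, a lower number a stronger effect. Compound 3 stands lowest of the three numbers: there is a number 13 percentage points lower from compound 1 to compound 3 (beyond the scatter) and a number 13 percentage points lower from compound 2 to compound 3 (beyond the scatter), each beyond the scatter, while there is no change at the digits printed from compound 1 to compound 2 (within the scatter).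

Compound 4 `O=C1CSC(c2cccc(F)c2)N1CCN1CCCCC1` has not been measured. It differs from compound 3 by 3-fluorophenyl in place of 4-fluorophenyl on a saturated ring carbon. The two steps that bear on this are those into compound 3, in which 4-fluorophenyl replaced 3-chlorophenyl or 3-hydroxyphenyl, and both gave a modest drop. Moving to 3-fluorophenyl runs back in the direction of compound 1 and compound 2, so a modest upward step is expected, a number 9 percentage points higher from compound 3 to compound 4 (within the scatter). Compound 4 is thus expected to give 96%, within 85% to 100%.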

Compound 4, a percentage reported as activity, at one concentration (the size of the read-out at that concentration, not a potency): 92%
Compound 4: middle estimate off by 4 percentage points, on the high side, within the range that was stated.
By their numbers in this assay, from the lowest: compounds 3, 4, 1 and 2 (each within the scatter of the next, the first and the last beyond it).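

In this assay there is a number 5 percentage points higher from compound 3 to compound 4 (within the scatter) when 3-fluorophenyl stands in place of 4-fluorophenyl on this saturated ring carbon, so moving the fluoro around the phenyl ring does not separate the two compounds. With the substituent kept in the same place on the phenyl ring, fluoro in place of chloro gives a number 8 percentage points lower from compound 1 to compound 4 (within the scatter) and fluoro in place of hydroxy gives a number 8 percentage points lower from compound 2 to compound 4 (within the scatter) so neither exchange alone goes beyond the scatter, unlike the steps into compound 3, which changed group and place together. On these data alone, whether an amine or a carboxylic acid on the phenyl ring would give a step beyond the scatter stays open. Nothing available explains these small steps.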